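Swapping the imide for a phenyl ring on the ester

The source may hold more compounds than are shown below. What is called first, only, known or untested is meant among the compounds shown, and "the series" means these compounds.

Measured so far:
Compound 1 `CC1(C)CC(=O)N(c2ccccc2C(=O)OCC2CCCN(CCCc3ccccc3)C2)C1=O` gives 7500 nM in a functional assay with Neuronal acetylcholine receptor; alpha3/beta4 (Homo sapiens) as the target; on this read-out higher numbers stand for weaker inhibition and lower numbers for stronger inhibition.
Compound 2 `C=CCC1CC(=O)N(c2ccccc2C(=O)OCC2CCCN(CCCc3ccccc3)C2)C1=O` gives 1700 nM in this assay.

Both compounds share the same ester-linked core and differ only in the five-membered ring attached to the aromatic carbon. Going by the values given here, the single step seen, a 4.4-fold lower number from compound 1 to compound 2 (0.64 log units; beyond the scatter), shows that changing the substituents on that ring moves the number by a modest amount. Among the compounds with values here, on the two numbers so far, compound 2 stands lowest, with compound 1 as its only neighbour.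

Compound 3 `O=C(OCC1CCCN(CCCc2ccccc2)C1)c1ccccc1-c1ccccc1` is not yet measured. It differs from compound 2 by a group of 6 heavy atoms (6 carbon; one six-membered aromatic ring of carbon only) in place of a group of 10 heavy atoms (7 carbon, 1 nitrogen, 2 oxygen; one five-membered non-aromatic ring with 1 hetero atom), on an aromatic carbon. The change sits on an aromatic carbon of a six-membered aromatic ring of carbon only. Within the data shown here, no measured step removes the five-membered ring altogether, so the one available step, a 4.4-fold lower number from compound 1 to compound 2 (0.64 log units; beyond the scatter), bears on it only loosely: it shows the site tolerates alteration at a modest scale. Compound 3 is therefore expected to land with a step of a 1.8-fold higher number from compound 2 to compound 3 (0.25 log units; within the scatter), weaker than compound 2 but within a wide band. The estimate for compound 3 in this assay is 3000 nM, with a range from 600 nM to 15000 nM.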

Compound 3, half-maximal inhibitory concentration: 1700 nM
Estimate against measurement, compound 3: 1.8-fold (0.25 log units) above; low and high end bracket the measured number.
By their numbers in this assay, from the lowest: compounds 2 and 3 (each within the scatter of the next); then compound 1.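

In this assay, a plain phenyl ring takes the place of the whole five-membered ring with almost no consequence, with no change at the digits printed from compound 2 to compound 3 (within the scatter), so this position on the aromatic carbon does not need that ring, its allyl-type side chain or its 2 hydrogen-bond acceptors to reach this level. Going by these compounds alone, the same phenyl group, set against the dimethyl-bearing ring, gives a 4.4-fold lower number from compound 1 to compound 3 (0.64 log units; beyond the scatter), which leaves compound 1 as the one compound of the three that stands apart, while a very different group matches compound 2 within the scatter. Nothing measured here explains why these two quite different groups end up level, or why compound 1 sits apart from them.

Going by these compounds, it remains open whether any ring is needed at this place at all, a question that a single methyl group, an amine or a carboxylic acid on the same aromatic carbon could address. On these data alone, it is also open whether a phenyl ring carrying a methoxy group or a fluorine atom would move the number beyond the level shared by compound 2 and compound 3.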